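Working notes: from compound 3 to compound 4

The source may hold more compounds than are shown below. What is called first, only, known or untested is meant among the compounds shown, and "the series" means these compounds.

Measured in an ADME assay on HEK293 cells (Homo sapiens) for cytotoxicity, with a stated time of 72 h; a lower number here means that less compound is needed, a higher number that more compound is needed for the effect:
- compound 1 `C=C[C@@](C)(/C=C/c1ccc(OS(=O)(=O)C(F)(F)F)cc1)CCC=C(C)C`: > 36600 nM
- compound 2 `C=C[C@](C)(CCCC(C)C)CCc1ccc(O)cc1`: > 36600 nM
- compound 3 `C=C[C@@](C)(/C=C/c1ccc(O)cc1)CCC1OC1(C)C`: > 36600 nM

All three entries are limits of the assay, not numbers. For the measured compounds named here, the series so far offers only (the limit of > 36600 nM in this assay, at which 3 of the 3 values shown sit). Compound 3 stands at > 36600 nM, which is likewise a limit. Compound 4 `C=C[C@@](C)(/C=C/c1ccc(O)cc1)CCCO` carries hydroxymethyl in place of 3,3-dimethyloxiran-2-yl on a saturated chain carbon, three bonds along the chain from two double-bonded chain carbons. Going by the values given here, no measured step is available, and no change beyond the scatter is expected in this assay. The estimated step that the limit leaves unreadable from compound 3 to compound 4 stays within that scatter. For compound 4 the estimated value is 40000 nM, with an expected range of 15000 nM to 80000 nM.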

Compound 4, half-maximal effective concentration: > 36600 nM
Compound 4 was reported as a limit; the forecaster's own chance of this, stated with the estimate: 75%; the middle value lies beyond the limit too.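

Compound 3 and compound 4 are both reported as limits, not numbers, so no step can be read between them. The compounds shown leave open whether any change in this series shifts the read-out at all: the limit of > 36600 nM in this assay, at which 4 of the 4 values shown sit.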